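A Chloro-for-Hydroxy Swap Carried Onto a Second Core

The source may hold more compounds than are shown below. What is called first, only, known or untested is meant among the compounds shown, and "the series" means these compounds.

Three compounds were tested in a functional assay on cells (Cancer cell lines, Homo sapiens) for cytotoxicity; a higher number here means that more compound is needed for the effect, a lower number that less compound is needed. Compound 1 `Nc1nc(Cl)c2ncn(C3CC(CO)C(O)C3O)c2n1` carries a chloro group on its core. In this assay compound 1 reaches only the limit of > 100 ug/mL. Compound 2 `Nc1nc(O)c2ncn(C3CC(CO)C(O)C3O)c2n1` carries a hydroxy group at the same place. In this assay compound 2 likewise stops at the limit of > 100 ug/mL. Compound 3 `Nc1nc(O)c2nnn(C3CC(CO)C(O)C3O)c2n1` keeps the hydroxy group but sits on a different core; the difference between the two cores is not broken down here. In this assay compound 3 also reaches only the limit of > 100 ug/mL.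

The change from compound 2 to compound 1 is chloro in place of hydroxy on an aromatic carbon. Its step, a step that the two limits leave unreadable from compound 2 to compound 1, cannot be sized, as both ends are limits; what the three measured compounds share is the limit of > 100 ug/mL in this assay, at which 3 of the 3 values shown sit.

Compound 4 `Nc1nc(Cl)c2nnn(C3CC(CO)C(O)C3O)c2n1` has not yet been measured in this assay. It differs from compound 3 by chloro in place of hydroxy on an aromatic carbon, the same change as that from compound 2 to compound 1, with the same surroundings word for word. The measured pair gives no readable step, so the expectation for compound 4 rests on the limit of > 100 ug/mL in this assay, at which 3 of the 3 values shown sit, rather than on a sized step. Compound 4 is therefore expected to give about 200 ug/mL in this assay, most likely once more reported only as a limit. The step that this estimate means, a step that the limit leaves unreadable from compound 3 to compound 4, is expected to be small.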

Compound 4, concentration for half-maximal effect: 8 ug/mL
Beside the measured number, compound 4's estimate is 25-fold (1.40 log units) above it, and the stated range ends above it.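

On the second core, chloro in place of hydroxy on an aromatic carbon gives, in this assay, an at least 12-fold lower number from compound 3 to compound 4 (1.09 log units; beyond the scatter), and with this result compound 4 is the only one of the four compounds shown that does not sit at the limit: the limit of > 100 ug/mL in this assay, at which 3 of the 4 values shown sit. On the first core the same change joins compound 2 and compound 1, both of which are reported only as limits, so that step cannot be read and no size can be set beside the step on the second core. The series therefore shows that the change can have a large effect on one core, but it does not show whether the effect carries over from one core to the other, whether it is of like size on both, or what lies behind it.

The compounds shown leave open how other groups on the same aromatic carbon, such as a bromo, a methoxy or a thiol group, would read in this assay on either core. Among these compounds, with only one readable step, they also leave open whether the result on the second core belongs to chloro in particular or would extend to such neighbours.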